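Sulfonamide series: halogen swap on the aryl ring

The compounds below may be only part of what the source reports. "The series", "measured", "known", "first", "only" and "open" are said of these compounds alone.

Measured so far:
Compound 1 `COc1ccc(S(=O)(=O)Nc2cc(Cl)cc(Cl)c2)cc1N1CCNCC1`: 0.631 nM
Compound 2 `COc1ccc(Cl)cc1NS(=O)(=O)c1ccc(OC)c(N2CCNCC2)c1`: 1.26 nM
Compound 3 `COc1ccc(S(=O)(=O)Nc2cc(Br)cc(Cl)c2Cl)cc1N1CCNCC1`: 3.98 nM

In an assay on isolated protein for binding affinity to 5-hydroxytryptamine receptor 6 (Homo sapiens) (on this read-out higher numbers stand for weaker inhibition and lower numbers for stronger inhibition), compound 3 gives 3.98 nM, the highest of the three numbers. The steps of a 6.3-fold higher number from compound 1 to compound 3 (0.80 log units; beyond the scatter) and a 3.2-fold higher number from compound 2 to compound 3 (0.50 log units; beyond the scatter) both lie beyond the scatter, whereas a 2.0-fold higher number from compound 1 to compound 2 (0.30 log units; within the scatter) lies within it. Compound 4 `COc1ccc(S(=O)(=O)Nc2cc(Br)cc(Br)c2Cl)cc1N1CCNCC1` differs from compound 3 in one place: bromo in place of chloro on an aromatic carbon. Within the data shown here, no measured step exchanges one halogen for another on the same ring; the two steps leading to compound 3 each alter several groups at once and so give no direct reading on this change. A step within the scatter is expected, a 1.0-fold higher number from compound 3 to compound 4 (0.00 log units; within the scatter). Compound 4 is estimated at 4 nM, with a range from 1.8 nM to 9 nM.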

Compound 4, inhibition constant: 2.51 nM
The estimate for compound 4 lay 1.6-fold (0.20 log units) above the measured number, and the stated range covers the measured number.
By their numbers in this assay, from the lowest: compounds 1, 2, 4 and 3 (each within the scatter of the next, the first and the last beyond it).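

In this assay, bromo in place of chloro on an aromatic carbon, ortho to a chloro group, gives a 1.6-fold lower number from compound 3 to compound 4 (0.20 log units; within the scatter), so this single halogen exchange at this position registers no change. With 3,5-dibromo-2-chlorophenyl on the sulfonamide nitrogen, the comparisons are a 2.0-fold higher number from compound 2 to compound 4 (0.30 log units; within the scatter) and a 4.0-fold higher number from compound 1 to compound 4 (0.60 log units; beyond the scatter), which keeps only the gap to 3,5-dichlorophenyl outside the noise. No other data here bear on this result.

Going by these compounds, whether the other halogen sites tolerate the same exchange remains open. So does the outcome with an amine or a carboxylic acid at this position.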